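A few compounds are considered here, and "the series" means these few. Any claim that something is new, unique, unknown or untested is made for them only; others in the source may bear on it.

Three compounds share one core, and in a functional assay on HeLa cells (Homo sapiens) for cytotoxicity, read by MTT assay, with a stated time of 48 h (on this read-out higher numbers stand for weaker inhibition and lower numbers for stronger inhibition), compound 1 `O=C(Nc1nc2ccc(F)cc2s1)c1cc(-c2ccc(F)cc2)n2nc(-c3ccccc3)cc2n1` gives 29500 nM, compound 2 `COc1ccc(-c2cc(C(=O)Nc3nc4ccc(F)cc4s3)nc3cc(-c4ccccc4)nn23)cc1` gives 41700 nM, and compound 3 `COc1ccc(-c2cc(C(=O)Nc3nc4ccc(F)cc4s3)nc3cc(-c4ccccc4)nn23)cc1OC` gives 8310 nM, the lowest number of the three. Going a 1.4-fold higher number from compound 1 to compound 2 (0.15 log units; within the scatter) stays within the scatter, whereas going a 3.5-fold lower number from compound 1 to compound 3 (0.55 log units; beyond the scatter) and going a 5.0-fold lower number from compound 2 to compound 3 (0.70 log units; beyond the scatter) both lower the number. Compound 4 `COc1cc(-c2cc(C(=O)Nc3nc4ccc(F)cc4s3)nc3cc(-c4ccccc4)nn23)cc(OC)c1OC` differs from compound 3 by methoxy in place of hydrogen on an aromatic carbon. For the measured compounds named here, the step most like it is the one from compound 2 to compound 3, where the same kind of addition brought a modest lowering. A smaller lowering of similar direction is therefore expected, with the step from compound 3 to compound 4 estimated as a 1.8-fold lower number from compound 3 to compound 4 (0.27 log units; within the scatter). For compound 4 in this assay the value is expected to be 4500 nM, likely between 1500 nM and 15000 nM.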

Compound 4, half-maximal inhibitory concentration: 25100 nM
Compound 4: middle estimate off by 5.6-fold (0.75 log units), on the low side, and the stated range ends below it.
By their numbers in this assay, from the lowest: compound 3; then compounds 4, 1 and 2 (each within the scatter of the next).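

In this assay a further methoxy on this ring does not keep lowering the number: going from 3,4-dimethoxyphenyl to 3,4,5-trimethoxyphenyl gives a 3.0-fold higher number from compound 3 to compound 4 (0.48 log units; beyond the scatter) and so runs against the earlier addition. The steps of a 1.7-fold lower number from compound 2 to compound 4 (0.22 log units; within the scatter) and a 1.2-fold lower number from compound 1 to compound 4 (0.07 log units; within the scatter) both lie within the scatter, so the 3,4,5-trimethoxyphenyl compound cannot be told apart from those two. Nothing measured here accounts for this reversal.

Still open, going by these compounds, is whether another group in that place, such as a hydroxyl, an amine or a longer ethoxy chain, would raise the number as this methoxy did or keep it low.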